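Biphenyl pyrazoles against OVCAR growth: an amine in place

The source may hold more compounds than are shown below. What is called first, only, known or untested is meant among the compounds shown, and "the series" means these compounds.

Measured so far:
Compound 1, `O=[N+]([O-])c1ccc(-c2cc(-c3ccc(Br)cc3)n[nH]2)cc1`, 17500 nM
Compound 2, `FC(F)(F)c1ccc(-c2cc(-c3ccccc3-c3ccccc3)n[nH]2)cc1`, 2750 nM
Compound 3, `COc1cccc(-c2cc(-c3ccccc3-c3ccccc3)n[nH]2)c1`, 5800 nM

The three compounds were tested in a functional assay on OVCAR cells (Homo sapiens) for inhibition, read by MTT assay, with a stated time of 48 h; a higher number here means a weaker inhibitor of growth, a lower number a stronger inhibitor of growth. Compound 1 gives 17500 nM, the highest of the three numbers. Compound 2 gives 2750 nM, the lowest. Compound 3 gives 5800 nM, the second highest; its gap to compound 2 and its gap to compound 1 both lie beyond the scatter of this assay.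

The next compound, compound 4, is `Nc1ccc(-c2cc(-c3ccccc3-c3ccccc3)n[nH]2)cc1`. It differs from compound 3 in one place: 4-aminophenyl in place of 3-methoxyphenyl on an aromatic carbon. For the measured compounds named here, no pair among the measured compounds shows this change, so nothing here tells how an aminophenyl group compares with a methoxyphenyl group at that position. The spread of the three measured numbers is modest, and the change does not touch the shared core, so a small step is expected, in either direction, perhaps not beyond the scatter. The estimated step from compound 3 to compound 4 is a 1.2-fold higher number from compound 3 to compound 4 (0.08 log units; within the scatter). Compound 4 is expected to give about 7000 nM in this assay, with a plausible range from 2500 nM to 20000 nM.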

Compound 4, concentration for 50% growth inhibition: 17900 nM
Compound 4: the middle estimate sits 2.6-fold (0.41 log units) below what was measured; measured number inside the range.
By their numbers in this assay, from the lowest: compound 2; then compound 3; then compounds 1 and 4 (each within the scatter of the next).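

In this assay, the first step measured at this aromatic carbon shows that the change is not neutral: 4-aminophenyl in place of 3-methoxyphenyl gives a 3.1-fold higher number from compound 3 to compound 4 (0.49 log units; beyond the scatter). Amino in place of trifluoromethyl on the aromatic carbon gives a 6.5-fold higher number from compound 2 to compound 4 (0.81 log units; beyond the scatter), so of these three compounds sharing the core, compound 4 has the highest number. Nothing measured here accounts for either step.

The compounds shown leave open whether the amino group or its ring position carries the first step, as 3-methoxyphenyl and 4-aminophenyl differ in both, and a 3-aminophenyl or 4-methoxyphenyl group would separate the two. Also open, as far as these compounds go, is whether a 4-dimethylaminophenyl or 4-acetamidophenyl group at this place would read like 4-aminophenyl.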